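From cyclopropyl to (4-chlorophenyl)amino on the carbonyl carbon

The compounds below may be only part of what the source reports. "The series", "measured", "known", "first", "only" and "open" are said of these compounds alone.

In a functional assay on HT-29 cells (Homo sapiens) for inhibition, read by MTT assay, with a stated time of 48 h (a higher number here means a weaker inhibitor, a lower number a stronger inhibitor), compound 1 `CCSc1nnc(-c2cc(OC)c(OC)c(OC)c2)n1-c1ccc(OC)cc1` gives > 60000 nM, a limit of the assay. Compound 2 `COc1ccc(-n2c(SCC(=O)C3CC3)nnc2-c2cc(OC)c(OC)c(OC)c2)cc1` gives > 60000 nM, also a limit, so its standing has no readable number. Going by the values given here, the only measured step, a step that the two limits leave unreadable from compound 1 to compound 2, has no readable size. Among the compounds with values here, the series so far shows only (the limit of > 60000 nM in this assay, at which 2 of the 2 values shown sit). Compound 3 `COc1ccc(-n2c(SCC(=O)Nc3ccc(Cl)cc3)nnc2-c2cc(OC)c(OC)c(OC)c2)cc1` carries (4-chlorophenyl)amino in place of cyclopropyl on a carbonyl carbon. With no measured size as a guide, the expected step is an at least 2.4-fold lower number from compound 2 to compound 3 (0.38 log units; beyond the scatter), towards stronger inhibition in this assay, and a result at the limit remains quite possible. For compound 3 the estimate is 25000 nM, with an expected range from 3000 nM to 60000 nM.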

Compound 3, half-maximal inhibitory concentration: 58000 nM
Compound 3: the middle estimate sits 2.3-fold (0.37 log units) below what was measured; measured number inside the range.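

In this assay, going by these compounds alone, compound 3 gives 58000 nM, the only number that is not a limit, so (4-chlorophenyl)amino on the carbonyl carbon yields the first readable value at this position. The steps are only floors, an at least 1.0-fold lower number from compound 2 to compound 3 (0.01 log units; that floor lies within the scatter) and an at least 1.0-fold lower number from compound 1 to compound 3 (0.01 log units; that floor lies within the scatter), so no real gain in inhibition is established. Most of the series still stands at the edge of the assay: the limit of > 60000 nM in this assay, at which 2 of the 3 values shown sit.

Still open, going by these compounds, is whether plain phenylamino without the chlorine, a dimethylamino group or a hydroxyl on the same carbonyl carbon would give a number clearly beyond the scatter.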